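The compounds below may be only part of what the source reports. "The series", "measured", "known", "first", "only" and "open" are said of these compounds alone.

In a functional assay on NCI-H1993 cells (Homo sapiens) for inhibition, read by CCK-8 assay, with a stated time of 72 h (a lower number here means a stronger inhibitor, a higher number a weaker inhibitor), compound 1 (`CC(c1cc2cccnc2cc1F)n1cnc2ncc(-c3cnn(CCO)c3)nc21`) gives 175 nM and compound 2 (`CC(c1c(F)cc2ncccc2c1F)n1cnc2ncc(-c3cnn(CCO)c3)nc21`) gives 83.7 nM, the lower of the two numbers available. For compound 3 (`CCC(c1cc2cccnc2cc1F)n1cnc2ncc(-c3ccccc3)nc21`) the result stands as "not determined" (no result reported), so it offers no guide. Compound 4 (`CC(c1c(F)cc2ncccc2c1F)n1cnc2ncc(-c3cnc4ccccc4c3)nc21`) differs from compound 2 by one change: quinolin-3-yl in place of 1-(2-hydroxyethyl)-1H-pyrazol-4-yl on an aromatic carbon. Within the data shown here, the only measured step, a 2.1-fold lower number from compound 1 to compound 2 (0.32 log units; beyond the scatter), is fluoro in place of hydrogen on an aromatic carbon and does not touch this group, so it bears on the change only weakly. Among the measured compounds shown here, no measured pair varies this group. In this assay, a moderate move toward a higher number is therefore expected, though with wide uncertainty, giving an expected 3.6-fold higher number from compound 2 to compound 4 (0.55 log units; beyond the scatter). Compound 4 is estimated at 300 nM, with an expected range of 50 nM to 1500 nM.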

Compound 4, half-maximal inhibitory concentration: 46.1 nM
Compound 4: middle estimate off by 6.5-fold (0.81 log units), on the high side; the whole stated range lies above it.
By their numbers in this assay, from the lowest: compounds 4 and 2 (each within the scatter of the next); then compound 1.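

In this assay, the swap at this aromatic carbon gives a 1.8-fold lower number from compound 2 to compound 4 (0.26 log units; within the scatter), so quinolin-3-yl and 1-(2-hydroxyethyl)-1H-pyrazol-4-yl are not separated here. On this core, the position therefore accepts a group of two fused aromatic rings with 0 hydrogen-bond donors, and the hydroxyl-bearing chain is not needed to keep the number in this range. Nothing on hand explains this result. On these data alone, what an amine or a carboxylic acid at this carbon would give remains open. Also open, as far as these compounds go, is whether quinolin-3-yl behaves the same way on the core of compound 1.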